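The compounds below may be only part of what the source reports. "The series", "measured", "known", "first", "only" and "open" are said of these compounds alone.

Compounds measured in an assay on isolated protein for inhibition of Polyunsaturated fatty acid 5-lipoxygenase (Homo sapiens), tested at 10 uM; on this read-out lower numbers stand for less inhibition and higher numbers for more inhibition at the one concentration tested (going by the name of the read-out):
- compound 1, `CCOC(=O)c1c(N2CCN(c3ccc(F)cc3)CC2)[nH]c2ccc(O)cc12`: 81%
- compound 2, `CCOC(=O)c1c(N2CCN(c3ccc(Cl)cc3)CC2)[nH]c2ccc(O)cc12`: 69%

For the measured compounds named here, compound 2 stands lowest of the two numbers so far. Going by the values given here, its nearest neighbour is compound 1, and the one step that joins them is a number 12 percentage points lower from compound 1 to compound 2 (beyond the scatter). Compound 3, `CCOC(=O)c1c(N2CCN(c3ccc(Cc4ccccc4)cc3)CC2)[nH]c2ccc(O)cc12`, has not been measured yet. Compared with compound 2 it carries benzyl in place of chloro on an aromatic carbon.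

Among the compounds with values here, the only step on record concerns the same position on the same ring, where a small change from one halogen to another already produced a modest drop. Within the data shown here, that step is the sole guide here, and it does not bear directly on a change to a group of this size. Taken as a weak hint that enlarging the group at this spot costs inhibition, the estimated outcome is a further drop, a number 14 percentage points lower from compound 2 to compound 3 (beyond the scatter), though a change this different from anything measured leaves the direction uncertain. Compound 3 is therefore expected to give about 55% in this assay, with a wide range from 25% to 82%.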

Compound 3, a percentage reported as inhibition, at one concentration (the size of the read-out at that concentration, not a potency): 61%
Compound 3: the middle estimate sits 6 percentage points below what was measured; the range from low to high includes it.
By their numbers in this assay, from the lowest: compounds 3 and 2 (each within the scatter of the next); then compound 1.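

In this assay, for the compounds shown here, putting a benzyl, with its additional six-membered aromatic ring, in place of the single chlorine gives a number 8 percentage points lower from compound 2 to compound 3 (within the scatter), so compound 2 and compound 3 cannot be told apart on this read-out. The earlier pair compared only two halogens, whereas this result shows that the aromatic carbon para to a large group can carry a much bigger group, with 7 heavy atoms instead of 1, without a change beyond the scatter. Measured against the fluoro compound, the same group gives a number 20 percentage points lower from compound 1 to compound 3 (beyond the scatter) and that gap is beyond the scatter, so compound 1 stays apart from compound 3 as it does from compound 2, and the three compounds together do not support a simple rule that a larger group here means less inhibition.

Going by these compounds, what an amine, a carboxylic acid or a longer carbon chain would give at this carbon remains open, as does whether any such group could match or pass compound 1 in this test. Nothing at hand offers an explanation for these numbers.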